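The compounds below may be only part of what the source reports. "The series", "measured", "known", "first", "only" and "open" are said of these compounds alone.

Compound 1 `COc1ccc(-c2nc3cc(C)ccn3c2Nc2cc(OC)c(OC)c(OC)c2)cc1O`: 48000 nM
Compound 2 `COc1ccc(-c2nc3cnccn3c2Nc2cc(OC)c(OC)c(OC)c2)cc1O`: 50000 nM

These two compounds have been measured in an ADME assay on Vero cells (Chlorocebus sabaeus) for cytotoxicity, read by MTT assay; on this read-out higher numbers stand for lower toxicity in this test and lower numbers for higher toxicity in this test. Compound 2 gives 50000 nM, the higher number of the pair only on paper, since compound 1, at 48000 nM, lies within the scatter of it. The two values therefore cannot be ranked.

Compound 3 `COc1ccc(-c2nc3cnccn3c2Nc2cc(OC)c(OC)c(OC)c2)cc1` keeps the core of compound 2 and carries one change hydrogen in place of hydroxy on an aromatic carbon, taking 3-hydroxy-4-methoxyphenyl to 4-methoxyphenyl. Going by the values given here, no measured pair shows this change, so the data give no direct guide to its size. No shift beyond the scatter is expected in this assay. The estimated 1.2-fold higher number from compound 2 to compound 3 (0.08 log units; within the scatter) stays small, with no firm direction. Compound 3 is expected at 60000 nM, within an estimated range of 22000 nM to 150000 nM.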

Compound 3, concentration lethal to 50% of the cells: 75000 nM
Compound 3: the middle estimate sits 1.3-fold (0.10 log units) below what was measured; measured number inside the range.
By their numbers in this assay, from the lowest: compounds 1, 2 and 3 (each within the scatter of the next).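

Going by these compounds alone, the change of 3-hydroxy-4-methoxyphenyl to 4-methoxyphenyl gives the first direct reading at this position in this assay (a 1.5-fold higher number from compound 2 to compound 3 (0.18 log units; within the scatter)). On the core of compound 2, the hydroxy group on this aromatic carbon, ortho to a methoxy group, can therefore give way to hydrogen without a shift that can be told from the scatter, even though the change takes away a hydrogen-bond donor and a hydrogen-bond acceptor. Nothing available explains the small size of this step or says whether it has any direction.

The compounds shown leave open whether an amine, a fluorine atom or a longer alkoxy chain on this carbon would move the number beyond the scatter. They also leave open whether the same replacement of hydroxy by hydrogen would stay as small on the core of compound 1.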